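The source may hold more compounds than are shown below. What is called first, only, known or untested is meant among the compounds shown, and "the series" means these compounds.

The measured compounds in an assay on isolated protein for displacement of a labelled ligand from melanin-concentrating hormone receptor 1 (Homo sapiens); a higher number here means a weaker inhibitor, a lower number a stronger inhibitor:
- compound 3, `CN(C)c1ccc2cc(NC(=O)CCc3ccc(C(F)(F)F)cc3)ccc2n1`: 13 nM
- compound 1, `O=C(CCc1ccc(C(F)(F)F)cc1)Nc1ccc2nc(N3CC4CC3CN4)ccc2c1`: 210 nM
- compound 2, `CCCN(CCC)c1ccc2cc(NC(=O)CCc3ccc(C(F)(F)F)cc3)ccc2n1`: 490 nM

Compound 3 has the lowest number of the three in this assay: the step of a 16-fold lower number from compound 1 to compound 3 (1.21 log units; beyond the scatter) and the step of a 38-fold lower number from compound 2 to compound 3 (1.58 log units; beyond the scatter) are both large and beyond the scatter, so compound 3 is the strongest inhibitor of this set. Compound 4, `O=C(CCc1ccc(C(F)(F)F)cc1)Nc1ccc2nc(N3CCCCCC3)ccc2c1`, has not yet been measured. It differs from compound 3 in one place: azepan-1-yl in place of dimethylamino on an aromatic carbon. For the measured compounds named here, two measured steps bear on this change. The step of a 38-fold lower number from compound 2 to compound 3 (1.58 log units; beyond the scatter) shows that replacing dimethylamino with a larger open-chain dialkylamino group raises the number a great deal, and the step of a 16-fold lower number from compound 1 to compound 3 (1.21 log units; beyond the scatter) shows the same direction for a bicyclic group of the same heavy-atom count as azepan-1-yl. Between those two larger groups the step of a 2.3-fold higher number from compound 1 to compound 2 (0.37 log units; beyond the scatter) is only modest. Azepan-1-yl matches both in heavy-atom count and resembles the bicyclic group in having a ring, so a rise in this assay beyond the scatter is expected for compound 4, though it need not reach as far as compound 2 did. The expected step is an 8.5-fold higher number from compound 3 to compound 4 (0.93 log units; beyond the scatter). Compound 4 is therefore estimated at 110 nM, with a range from 30 nM to 400 nM.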

Compound 4, half-maximal inhibitory concentration: 36 nM
For compound 4 the middle estimate is 3.1-fold (0.49 log units) above the measured one; the range from low to high includes it.
By their numbers in this assay, from the lowest: compound 3; then compound 4; then compound 1; then compound 2.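

For the compounds shown here, at this position, next to the ring nitrogen, this assay accepts the seven-membered azepan-1-yl ring in place of dimethylamino with only a 2.8-fold higher number from compound 3 to compound 4 (0.44 log units; beyond the scatter) and no larger rise, so a gain in heavy atoms need not cost as much as the earlier compounds suggested. Heavy-atom count alone does not set the number here, since groups of equal count separate widely: azepan-1-yl in place of dipropylamino gives a 14-fold lower number from compound 2 to compound 4 (1.13 log units; beyond the scatter) and azepan-1-yl in place of the bicyclic group gives a 5.8-fold lower number from compound 1 to compound 4 (0.77 log units; beyond the scatter) as well. Nothing on hand explains why these groups of equal size differ.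

The compounds shown leave open how the number moves with ring size, as pyrrolidin-1-yl and piperidin-1-yl would fall between dimethylamino and azepan-1-yl in heavy-atom count, and whether diethylamino would sit closer to dimethylamino or to dipropylamino among the open-chain groups. They also leave open whether the second ring nitrogen of the bicyclic group or its bridged shape accounts for its distance from azepan-1-yl, which a simple piperazine or homopiperazine ring at the same place would help to separate.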